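Naphthyl in place of phenyl on the free sulfonamide

A few compounds are considered here, and "the series" means these few. Any claim that something is new, unique, unknown or untested is made for them only; others in the source may bear on it.

Compound 1 `CN(c1ccccc1)S(=O)(=O)c1ccc2c(c1)sc(=O)n2CCN1CCCC1`: 10%
Compound 2 `CN(c1cccc2ccccc12)S(=O)(=O)c1ccc2c(c1)sc(=O)n2CCN1CCCC1`: 40%
Compound 3 `O=c1sc2cc(S(=O)(=O)Nc3ccccc3)ccc2n1CCN1CCCC1`: 37%

Of the compounds shown here, three sharing one core have been measured in an assay on HEK293 cells for displacement of a labelled ligand from 5-hydroxytryptamine receptor 6 (Homo sapiens), read by radioligand binding, with a stated time of 60 min, tested at 100 nM; on this read-out lower numbers stand for less inhibition and higher numbers for more inhibition at the one concentration tested (going by the name of the read-out). Compound 3 sits second highest of the three numbers. Its nearest neighbour is compound 2, whose value lies within the scatter of that of compound 3, so no order between the two can be read. The furthest is compound 1: there is a modest step of a number 27 percentage points higher from compound 1 to compound 3 (beyond the scatter), which follows from hydrogen in place of methyl on a sulfonamide nitrogen.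

Compound 4 `O=c1sc2cc(S(=O)(=O)Nc3cccc4ccccc34)ccc2n1CCN1CCCC1` is the unmeasured member. It differs from compound 3 by naphthalen-1-yl in place of phenyl on a sulfonamide nitrogen.

Within the data shown here, one measured step bears directly on this change. Within the methylated pair, the same exchange of groups gave the modest rise a number 30 percentage points higher from compound 1 to compound 2 (beyond the scatter). If that rise carries over to the pair with a free sulfonamide nitrogen, a rise of comparable size is expected in this assay, that is, a step of a number 23 percentage points higher from compound 3 to compound 4 (beyond the scatter) is estimated. Whether the two gains add fully cannot be told from three compounds, so the range is kept wide.

Compound 4 is therefore expected to give about 60%, estimated between 40% and 80%.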

Compound 4, a percentage reported as inhibition, at one concentration (the size of the read-out at that concentration, not a potency): 0%
Estimate against measurement, compound 4: 60 percentage points above; the whole stated range lies above it.
By their numbers in this assay, from the lowest: compounds 4 and 1 (each within the scatter of the next); then compounds 3 and 2 (each within the scatter of the next).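

The exchange of phenyl for naphthalen-1-yl on a sulfonamide nitrogen has no fixed effect in this assay. With hydrogen on that nitrogen it gives a number 37 percentage points lower from compound 3 to compound 4 (beyond the scatter), so its direction depends on whether hydrogen or methyl is also present: the same change on two cores in this assay, a number 30 percentage points higher (beyond the scatter) from compound 1 to compound 2 and a number 37 percentage points lower (beyond the scatter) from compound 3 to compound 4, 67 percentage points apart, beyond the scatter of two such steps

Hydrogen in place of methyl on the same nitrogen likewise reverses with the group alongside it, and with naphthalen-1-yl present the step is a number 40 percentage points lower from compound 2 to compound 4 (beyond the scatter), so neither change can be read on its own: the same change on two cores in this assay, a number 27 percentage points higher (beyond the scatter) from compound 1 to compound 3 and a number 40 percentage points lower (beyond the scatter) from compound 2 to compound 4, 67 percentage points apart, beyond the scatter of two such steps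

The two rises seen singly therefore do not combine, as compound 4, which carries both changes, gives 0%.

The compounds shown leave open whether this pattern belongs to naphthalen-1-yl alone or would also appear with naphthalen-2-yl or benzyl on the sulfonamide nitrogen. They also leave open how an ethyl group in place of methyl on that nitrogen would behave with either phenyl or naphthalen-1-yl, and the reading at one concentration gives no potency for any of these compounds.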